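Phenylsulfonyl in place of (4-chlorophenyl)carbonyl: working notes

A few compounds are considered here, and "the series" means these few. Any claim that something is new, unique, unknown or untested is made for them only; others in the source may bear on it.

Measured in a functional assay on ID8 cells (Mus musculus) for antiproliferative activity; a lower number here means a stronger inhibitor, a higher number a weaker inhibitor:
- compound 1 `O=C(Nc1ccc(O)c2c(=O)cc(-c3ccccc3Cl)oc12)c1ccc(Cl)cc1`: 5500 nM
- compound 2 `O=C(Nc1c(O)cc(O)c2c(=O)cc(-c3ccccc3Cl)oc12)c1ccc(Cl)cc1`: "not determined" (no result reported)

For the measured compounds named here, compound 1 holds the only number, so it cannot yet be ranked against another compound. Compound 3 `O=c1cc(-c2ccccc2Cl)oc2c(NS(=O)(=O)c3ccccc3)ccc(O)c12` carries phenylsulfonyl in place of (4-chlorophenyl)carbonyl on a nitrogen on an aromatic ring. Going by the values given here, no measured step covers this change, so no shift beyond the scatter is expected in this assay, in either direction. The expected change is a 1.1-fold lower number from compound 1 to compound 3 (0.04 log units; within the scatter). For compound 3 the estimated value is 5000 nM, with an expected range of 1500 nM to 16000 nM.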

Compound 3, half-maximal inhibitory concentration: 9500 nM
Beside the measured number, compound 3's estimate is 1.9-fold (0.28 log units) below it; the measured number falls inside the stated range.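

In this assay, for the compounds shown here, the nitrogen on an aromatic ring accepts phenylsulfonyl in place of (4-chlorophenyl)carbonyl with a 1.7-fold higher number from compound 1 to compound 3 (0.24 log units; within the scatter), so this is the first measured step at this position. The two groups cannot be told apart in this read-out, although the change replaces the carbonyl with a sulfonyl and also removes the chlorine. No available evidence bears on this result.

The compounds shown do not separate the carbonyl-to-sulfonyl change from the loss of chlorine. Also open, on these data alone, is how this position responds to a group without an aromatic ring, such as a simple alkyl chain or a carboxylic acid.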